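The source may report more compounds than this note shows. Statements on the series, on what has been measured and on what is new or still open speak of the compounds shown alone.

Compound 1 `COc1cc(-c2nccn2C(C)C)cc(OC)c1OC`: > 100000 nM
Compound 2 `COc1cc(-c2nccn2S(=O)(=O)c2ccccc2)cc(OC)c1OC`: > 100000 nM
Compound 3 `COc1cc(-c2nccn2-c2ccc3sccc3c2)cc(OC)c1OC`: 17000 nM

The three compounds were tested in a functional assay on T47D cells (Homo sapiens) for antiproliferative activity, read by MTT assay, with a stated time of 72 h; on this read-out lower numbers stand for stronger inhibition and higher numbers for weaker inhibition. Compound 1 gives only a limit there, > 100000 nM, and not a number. Compound 2 also gives only a limit, > 100000 nM. Together they stand at the limit of > 100000 nM in this assay, at which 2 of the 3 values shown sit. Compound 3 is the only one of the three with a number, 17000 nM.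

Compound 4 `COc1cc(-c2nccn2-c2cccc(C)c2)cc(OC)c1OC` has not yet been measured. It carries 3-methylphenyl in place of isopropyl on an aromatic nitrogen of the core of compound 1 (3-methylphenyl in place of isopropyl on an aromatic nitrogen).

Compound 3, at 17000 nM, also has an aromatic group on that nitrogen, which suggests that the change may bring a measurable value. Compound 2, whose group on that nitrogen also contains a ring, goes against this reading, so the expectation is a weak one.

In this assay, a modest step towards stronger inhibition is expected, an at least 3.3-fold lower number from compound 1 to compound 4 (0.52 log units; beyond the scatter), and a value at the limit remains possible. For compound 4 the estimated value is 30000 nM, with an expected range from 6000 nM to 100000 nM.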

Compound 4, half-maximal inhibitory concentration: 29300 nM
For compound 4 the middle estimate is 1.0-fold (0.01 log units) above the measured one, within the range that was stated.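

In this assay, among these compounds, 3-methylphenyl in place of isopropyl on an aromatic nitrogen of the shared core gives an at least 3.4-fold lower number from compound 1 to compound 4 (0.53 log units; beyond the scatter), the first step at this position that can be read at all. Compound 1 gives only a limit, > 100000 nM, so this step has a lower bound and no exact size. A ring on that nitrogen does not by itself bring a measurable value, since compound 2, which also carries a ring there, gives only a limit as well: the limit of > 100000 nM in this assay, at which 2 of the 4 values shown sit.

On these data alone, what the methyl group of 3-methylphenyl contributes remains open, as does how the value would respond to an amine or a carboxylic acid on that ring. As far as these compounds go, it is also open whether a longer chain on the same nitrogen would leave the value at the limit.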